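The source may hold more compounds than are shown below. What is called first, only, known or untested is meant among the compounds shown, and "the series" means these compounds.

The measured compounds and their values:

Compound 1, `Cc1[nH]c2ccc(Br)cc2c(=O)c1Br`, gives 95.3 10^-6 cm/s in an ADME assay for permeability, using PAMPA, at pH 7.4; a higher number here means that the compound crosses the layer faster, a lower number that the compound crosses the layer more slowly.
Compound 2, `Cc1[nH]c2ccc(Cl)cc2c(=O)c1Br`, gives 87.7 10^-6 cm/s in this assay.
Compound 3, `CCc1c(C)[nH]c2cc(OC)c(Cl)cc2c1=O`, gives 57.3 10^-6 cm/s in this assay.

Compounds 1 and 2 share a core and differ in one place: bromo in place of chloro on an aromatic carbon. That change gave a 1.1-fold higher number from compound 2 to compound 1 (0.04 log units; within the scatter), so the two values cannot be told apart. Compound 3 sits on another core, and how the two cores differ is not broken down here; its value lies within the scatter of both compound 2 and compound 1.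

Compound 4, `CCc1c(C)[nH]c2cc(OC)c(Br)cc2c1=O`, has not yet been measured in this assay. It differs from compound 3 in one place: bromo in place of chloro on an aromatic carbon. Among the measured compounds shown here, this is the same kind of change as the one from compound 2 to compound 1, but the surroundings are not identical: in compound 3 the aromatic carbon carrying the halogen is ortho to a methoxy group, which the core of compound 2 does not have.

For the measured compounds named here, the expectation for compound 4 rests on the one measured example of this change, where a 1.1-fold higher number from compound 2 to compound 1 (0.04 log units; within the scatter) stayed within the scatter. On that basis the step is expected to be small, a 1.1-fold higher number from compound 3 to compound 4 (0.03 log units; within the scatter), with the methoxy-bearing core of compound 3 adding some uncertainty. The estimated value for compound 4 in this assay is 62 10^-6 cm/s, likely between 40 10^-6 cm/s and 95 10^-6 cm/s.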

Compound 4, apparent permeability: 75.1 10^-6 cm/s
Compound 4: middle estimate off by 1.2-fold (0.08 log units), on the low side; the range from low to high includes it.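

In this assay, bromo in place of chloro on an aromatic carbon gave a 1.3-fold higher number from compound 3 to compound 4 (0.12 log units; within the scatter), so the two values cannot be told apart. Set beside the earlier example on the other core, the change carries across without a difference that can be read: the same change on two cores in this assay, a 1.1-fold higher number (0.04 log units; within the scatter) from compound 2 to compound 1 and a 1.3-fold higher number (0.12 log units; within the scatter) from compound 3 to compound 4, 1.2-fold (0.08 log units) apart, within the scatter of two such steps This shows only that on these two cores the swap of one halogen for the other leaves the read-out within the scatter; it does not show that the swap has any real effect on the read-out, that the methoxy group on the core of compound 3 has any influence on the step, or that the same would hold on a third core.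

The compounds shown leave open what happens on this aromatic carbon with a group other than chloro or bromo, such as an amine, a carboxylic acid or a fluoro group, and whether any of these would give a step beyond the scatter. They also leave open whether the halogen swap would read the same with a longer chain in place of the ethyl group of compound 3 and compound 4.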